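Chloro to fluoro swap on the shared core

This account rests on a few compounds, and the source may have more. Where it says the series, first, only, none or still open, it means among the compounds named here.

Working notes on the series. Compound 1 `O=S(=O)(Nc1ccc(-c2nc3cc(NS(=O)(=O)c4ccccc4O)ccc3o2)cc1)c1ccccc1O` carries two sulfonamide arms on the shared core; in an assay on cells for inhibition of HSP60/HSP10 (Homo sapiens), with a stated time of 60 min (on this read-out higher numbers stand for weaker inhibition and lower numbers for stronger inhibition), compound 1 gives 18000 nM. Compound 2 `O=S(=O)(Nc1ccc2oc(-c3ccccc3)nc2c1)c1ccccc1Cl` keeps one arm with a 2-chlorophenyl sulfonamide. In this assay compound 2 reaches only the limit of the measurement, > 100000 nM, so no number is known for it. Compound 3 `O=S(=O)(Nc1ccc2oc(-c3ccccc3)nc2c1)c1ccc(Cl)c(C(F)(F)F)c1` likewise sits at the limit, with > 100000 nM in this assay, again a limit and not a number. Thus compound 2 stands where most of the shown material stands, (the limit of > 100000 nM in this assay, at which 2 of the 3 values shown sit), and only compound 1 returns a number.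

Compound 4 `O=S(=O)(Nc1ccc2oc(-c3ccccc3)nc2c1)c1ccccc1F` differs from compound 2 in one place: fluoro in place of chloro on an aromatic carbon. Among the measured compounds shown here, no measured step of this kind is available among the three compounds, so the size of the change is not known from the data. With compound 2 at its limit, no step beyond the scatter is expected; the estimated step of a number no higher from compound 2 to compound 4 (the limit leaves the size open) is taken as flat. Compound 4 is accordingly expected to give 100000 nM, within an estimated range from 30000 nM to 300000 nM, most likely again as a limit.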

Compound 4, half-maximal inhibitory concentration: > 100000 nM
Compound 4 was reported as a limit; the forecaster's own chance of this, stated with the estimate: 80%; the middle value lies on the limit itself.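

No step can be read from compound 2 to compound 4, as both results are limits and not numbers: the limit of > 100000 nM in this assay, at which 3 of the 4 values shown sit.

The compounds shown leave open whether fluoro in place of chloro on an aromatic carbon changes inhibition in this assay at all.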